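This account rests on a few compounds, and the source may have more. Where it says the series, first, only, none or still open, it means among the compounds named here.

Compound 2 `Cc1ccc(S(=O)(=O)/N=C(/CCNC2=CC(=O)c3ccccc3C2=O)Nc2ccc(Cl)cc2)cc1` gives 7080 nM in a functional assay on MCF7 cells (Homo sapiens) for cytotoxicity, read by MTT assay, with a stated time of 48 h (on this read-out higher numbers stand for weaker inhibition and lower numbers for stronger inhibition), the second highest of the three numbers recorded; compound 1 `COc1ccc(N/C(CCNC2=CC(=O)c3ccccc3C2=O)=N\S(=O)(=O)c2ccc(C)cc2)cc1` sits nearest with 6030 nM, and compound 3 `Cc1ccc(S(=O)(=O)/N=C(/CCNC2=CC(=O)c3ccccc3C2=O)Nc2cccc(C(F)(F)F)c2)cc1` furthest with 89100 nM. The change from compound 2 to compound 4 `COc1cc(N/C(CCNC2=CC(=O)c3ccccc3C2=O)=N\S(=O)(=O)c2ccc(C)cc2)cc(OC)c1OC` is 3,4,5-trimethoxyphenyl in place of 4-chlorophenyl on an amine nitrogen. Among the compounds with values here, two measured steps bear on it. The step of a 1.2-fold higher number from compound 1 to compound 2 (0.07 log units; within the scatter) shows that the group on the amine nitrogen can be exchanged without moving the number, while a 13-fold higher number from compound 2 to compound 3 (1.10 log units; beyond the scatter) shows that another exchange cost much. The entering 3,4,5-trimethoxyphenyl resembles the 4-methoxyphenyl of compound 1 more than the 3-(trifluoromethyl)phenyl of compound 3. A modest move toward a higher number is expected, a 1.4-fold higher number from compound 2 to compound 4 (0.15 log units; within the scatter). Compound 4 is therefore estimated at 10000 nM, within 3000 nM to 40000 nM.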

Compound 4, half-maximal inhibitory concentration: 3050 nM
Compound 4: the middle estimate sits 3.3-fold (0.52 log units) above what was measured, within the range that was stated.
By their numbers in this assay, from the lowest: compounds 4, 1 and 2 (each within the scatter of the next, the first and the last beyond it); then compound 3.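

In this assay the 3,4,5-trimethoxyphenyl on the amine nitrogen stays level with the 4-methoxyphenyl of compound 1 (a 2.0-fold lower number from compound 1 to compound 4 (0.30 log units; within the scatter)), yet it separates from the 4-chlorophenyl (a 2.3-fold lower number from compound 2 to compound 4 (0.37 log units; beyond the scatter)), a difference that compound 1 and compound 2 had not shown between themselves. The distance to the 3-(trifluoromethyl)phenyl also grows (a 29-fold lower number from compound 3 to compound 4 (1.47 log units; beyond the scatter)). No measurement at hand accounts for these differences. The compounds shown leave open how a pyridine ring or a benzyl group on this nitrogen would compare, and whether a lone 3-methoxyphenyl would match the 3,4,5-trimethoxyphenyl.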